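A few compounds are considered here, and "the series" means these few. Any claim that something is new, unique, unknown or untested is made for them only; others in the source may bear on it.

Measured compounds:
Compound 1, `O=c1c(-c2nn[nH]n2)c[nH]c2ccccc12`. In a functional assay on the whole organism (strain Sprague-Dawley) for inhibition, with Rattus norvegicus as the target (on this read-out higher numbers stand for an effect only at larger amounts of compound and lower numbers for an effect already at smaller amounts), compound 1 gives > 20 mg/kg, which is a limit of the assay and not a number.
Compound 2, `O=c1c(-c2nn[nH]n2)c[nH]c2ccc(F)cc12`. In this assay compound 2 gives > 20 mg/kg, again a limit and not a number.

Compound 2 therefore stands at the limit, where every value shown so far sits, (the limit of > 20 mg/kg in this assay, at which 2 of the 2 values shown sit). For the measured compounds named here, the one measured step, a step that the two limits leave unreadable from compound 1 to compound 2, has no readable size, as both of its ends are limits.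

Compound 3, `CCc1ccc2[nH]cc(-c3nn[nH]n3)c(=O)c2c1`, is to be measured in this assay. Its change from compound 2 is ethyl in place of fluoro on an aromatic carbon. Going by the values given here, the only step that bears on this position is a step that the two limits leave unreadable from compound 1 to compound 2, and it gives no direction and no size. Nothing in the series points to an effect beyond the scatter in either direction.

The estimate rests on the fact that all values shown sit at the limit, (the limit of > 20 mg/kg in this assay, at which 2 of the 2 values shown sit). Compound 3 is accordingly expected to give about 30 mg/kg, within a range from 10 mg/kg to 100 mg/kg. The step that this estimate means, a step that the limit leaves unreadable from compound 2 to compound 3, is expected to stay within the scatter, and a further limit rather than a number is the likelier outcome.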

Compound 3, minimum effective dose: 0.625 mg/kg
Compound 3: the middle estimate sits 48-fold (1.68 log units) above what was measured, and the stated range ends above it.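

In this assay, this position turns out to respond to substitution: ethyl in place of fluoro gives an at least 32-fold lower number from compound 2 to compound 3 (1.50 log units; beyond the scatter), and ethyl in place of hydrogen gives an at least 32-fold lower number from compound 1 to compound 3 (1.50 log units; beyond the scatter). For the compounds shown here, compound 3 is thus the first compound with a number rather than a limit of the assay, and both steps are beyond the scatter, whereas the step between the two earlier compounds cannot be read, as both its ends are limits. Ethyl therefore separates itself from both hydrogen and fluoro here, though the true size of each step stays open, and the other two compounds remain at the limit: the limit of > 20 mg/kg in this assay, at which 2 of the 3 values shown sit.

Whether this gain is specific to ethyl stays open, as methyl, a longer chain such as propyl or butyl, an amine or a carboxylic acid at this position are not among the compounds shown. As far as these compounds go, it is also open whether ethyl on another aromatic carbon of the shared core would give a similar result.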